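Tetrazol-5-yl in place of (dimethylamino)methyl on the six-membered aromatic ring with 1 nitrogen

A few compounds are considered here, and "the series" means these few. Any claim that something is new, unique, unknown or untested is made for them only; others in the source may bear on it.

Of the compounds shown here, three sharing one core have been measured in a functional assay for antagonist activity at transient receptor potential cation channel subfamily V member 1 (Rattus norvegicus); on this read-out higher numbers stand for weaker inhibition and lower numbers for stronger inhibition. Compound 1 `CC(C)(C)c1ccc(NC(=O)c2ccc(-c3ncccc3NC3CCCC3)cc2)cc1` gives 44 nM, compound 2 `CCS(=O)(=O)Nc1cccnc1-c1ccc(C(=O)Nc2ccc(C(C)(C)C)cc2)cc1` gives 4 nM, and compound 3 `CN(C)Cc1cccnc1-c1ccc(C(=O)Nc2ccc(C(C)(C)C)cc2)cc1` gives 234 nM, the highest of the three. The steps of a 5.3-fold higher number from compound 1 to compound 3 (0.73 log units; beyond the scatter) and a 59-fold higher number from compound 2 to compound 3 (1.77 log units; beyond the scatter) show that the (dimethylamino)methyl group sits poorly here, while the groups of compounds 1 and 2, each carrying a hydrogen-bond donor, fare better. Compound 4 `CC(C)(C)c1ccc(NC(=O)c2ccc(-c3ncccc3-c3nn[nH]n3)cc2)cc1` makes the change (2H-tetrazol-5-yl in place of (dimethylamino)methyl on an aromatic carbon), which again brings a donor. A drop toward the numbers of compounds 1 and 2 is therefore expected. For compound 4 the expected step is roughly a 5.9-fold lower number from compound 3 to compound 4 (0.77 log units; beyond the scatter). For compound 4 in this assay the estimate is 40 nM, within 8 nM to 200 nM.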

Compound 4, half-maximal inhibitory concentration: > 4000 nM
Compound 4 gave a limit, no number; the forecaster's own chance of this, stated with the estimate: 5%; middle value at least 100-fold (2.00 log units) away from the limit.
By their numbers in this assay, from the lowest: compound 2; then compound 1; then compound 3. At a limit, above all of these: compound 4.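

In this assay compound 4 gives only a limit, not a number: the limit of > 4000 nM in this assay, at which 1 of the 4 values shown sits. The steps can still be read as minimum sizes: an at least 17-fold higher number from compound 3 to compound 4 (1.23 log units; beyond the scatter), an at least 90-fold higher number from compound 1 to compound 4 (1.95 log units; beyond the scatter) and an at least 1000-fold higher number from compound 2 to compound 4 (3.00 log units; beyond the scatter). A hydrogen-bond donor on this aromatic carbon therefore does not by itself bring strong inhibition, and compound 4 goes against the link between a donor and a low number seen in compounds 1 and 2.

As far as these compounds go, the true value of compound 4 stays unknown. Also open, from the compounds shown here alone, is whether a carboxylic acid at this place would behave like 2H-tetrazol-5-yl or like the (ethylsulfonyl)amino group of compound 2.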